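Swapping Allyl for Phenyl on an Aromatic Nitrogen

The source may report more compounds than this note shows. Statements on the series, on what has been measured and on what is new or still open speak of the compounds shown alone.

Of the compounds shown here, three have so far been tested in a functional assay on the whole organism (strain albino) for inhibition, with Rattus norvegicus as the target, read by paw edema, with stated times of 30 min and 1 h, at a dose of 0.28 mmol/kg by the oral route; a lower number here means less inhibition, a higher number more inhibition at the dose given (going by the name of the read-out). Compound 1, `C=CCn1c(SCC(=O)Nc2ccc(/C(C)=N/O)cc2)nnc1-c1ccccc1`, gives 61%. Compound 2, `C/C(=N\O)c1ccc(NC(=O)CSc2nnc(-c3ccccc3)n2-c2ccccc2)cc1`, gives 50%. Compound 3, `C=CCn1c(SCC(=O)Nc2ccc(C(C)=O)cc2)nnc1-c1ccc(OC)cc1`, gives 50%, which is level with compound 2 at the digits reported, so no order can be read between those two; compound 1 sits higher than both by an amount beyond the usual scatter.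

Compound 2 arises from compound 1 by a single change, (phenyl in place of allyl on an aromatic nitrogen). That change gave a number 11 percentage points lower from compound 1 to compound 2 (beyond the scatter), a modest drop.

Compound 4, `COc1ccc(-c2nnc(SCC(=O)Nc3ccc(C(C)=O)cc3)n2-c2ccccc2)cc1`, has not yet been measured. It arises from compound 3 by phenyl in place of allyl on an aromatic nitrogen. For the measured compounds named here, this is the same kind of change as the one leading from compound 1 to compound 2, but the surroundings are not identical: in compound 1 the aromatic nitrogen lies next to the ring atom that bears a phenyl group, whereas in compound 3 it lies next to the ring atom that bears a 4-methoxyphenyl group. How the core of compound 3 differs from the core of compound 1 is not broken down here.

Going by the values given here, only one earlier example of this change exists, namely a number 11 percentage points lower from compound 1 to compound 2 (beyond the scatter), so a step of similar size is expected, a number 9 percentage points lower from compound 3 to compound 4 (within the scatter). Compound 4 is therefore estimated at 41%. Because that single precedent is a number 11 percentage points lower from compound 1 to compound 2 (beyond the scatter) and the cores differ, the expected range is kept wide, from 28% to 54%.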

Compound 4, a percentage reported as inhibition, in the whole organism at one dose (the size of the read-out at that dose, not a potency): 29%
Compound 4: middle estimate off by 12 percentage points, on the high side; low and high end bracket the measured number.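

In this assay, putting phenyl in place of allyl on the aromatic nitrogen again lowered the number, giving a number 21 percentage points lower from compound 3 to compound 4 (beyond the scatter). Set beside the earlier case, the change points the same way on both cores, and the two steps cannot be told apart in size: the same change on two cores in this assay, a number 11 percentage points lower (beyond the scatter) from compound 1 to compound 2 and a number 21 percentage points lower (beyond the scatter) from compound 3 to compound 4, 10 percentage points apart, within the scatter of two such steps

So on these two cores the change carried over in direction, and the larger step on the core of compound 3 should not be read as a real difference between the cores; two pairs, however, make no general rule, and they neither say why the number falls nor show that it would fall on any other core.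

The compounds shown leave open how other groups on this same aromatic nitrogen would compare with allyl and phenyl, such as a methyl group, a longer chain such as butyl, or a benzyl group. On these data alone, each number is also a reading at a single dose, so it remains open whether the same drop would appear at other doses.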